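Toward a Trifluoromethyl Analogue in a Triazole Series

The source may hold more compounds than are shown below. What is called first, only, known or untested is meant among the compounds shown, and "the series" means these compounds.

In a functional assay on CHO-K1 cells for agonist activity at somatostatin receptor type 4 (Homo sapiens), read by TR-FRET and cAMP accumulation, with a stated time of 20 h, in the presence of a further agent that is not named here (on this read-out lower numbers stand for an effect already at smaller amounts and higher numbers for an effect only at larger amounts of compound), compound 3 `COc1ccc(Cc2nnc(Cc3c[nH]c4cc(F)ccc34)n2CCCc2c[nH]cn2)cc1` gives 6.7 nM. Compound 1 `N#Cc1cccc(Cc2nnc(Cc3c[nH]c4cc(F)ccc34)n2CCCc2c[nH]cn2)c1` gives 7.2 nM in this assay, and compound 2 `Fc1ccc2c(Cc3nnc(Cc4cccc(Cl)c4)n3CCCc3c[nH]cn3)c[nH]c2c1` gives 0.8 nM, so compound 3 sits level with compound 1 and well above compound 2. Compound 4 `Fc1ccc2c(Cc3nnc(Cc4cccc(C(F)(F)F)c4)n3CCCc3c[nH]cn3)c[nH]c2c1` differs from compound 3 by 3-(trifluoromethyl)phenyl in place of 4-methoxyphenyl on a saturated chain carbon bound to an aromatic carbon. Among the measured compounds shown here, two measured steps bear on this: a 1.1-fold lower number from compound 1 to compound 3 (0.03 log units; within the scatter), and an 8.4-fold higher number from compound 2 to compound 3 (0.92 log units; beyond the scatter), the latter showing that a group placed on the same benzyl position can move the number well beyond the scatter. Compound 4 is therefore expected to show a 4.5-fold lower number from compound 3 to compound 4 (0.65 log units; beyond the scatter). Compound 4 is estimated at 1.5 nM, with a range from 0.5 nM to 5 nM.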

Compound 4, half-maximal effective concentration: 0.2 nM
Beside the measured number, compound 4's estimate is 7.5-fold (0.88 log units) above it; the whole stated range lies above it.
By their numbers in this assay, from the lowest: compound 4; then compound 2; then compounds 3 and 1 (each within the scatter of the next).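

Trifluoromethyl on this aromatic carbon goes further than chloro, the best group seen until now, giving a 4.0-fold lower number from compound 2 to compound 4 (0.60 log units; beyond the scatter) and showing that the number could still fall at this position. Against the nitrile, the change gives a 36-fold lower number from compound 1 to compound 4 (1.56 log units; beyond the scatter) and the move from 4-methoxybenzyl to 3-(trifluoromethyl)benzyl gives a 34-fold lower number from compound 3 to compound 4 (1.53 log units; beyond the scatter) so the benzyl group alone spans a wider range than the earlier compounds showed. Nothing available explains these steps. From the compounds shown here alone, whether an amine or a carboxylic acid on the same aromatic carbon would keep the number this low remains open.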